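The source may hold more compounds than are shown below. What is called first, only, known or untested is meant among the compounds shown, and "the series" means these compounds.

Among the measured compounds shown here, compound 1 `O=C(Nc1ccc(F)c(Cl)c1)c1ccc2cn[nH]c2c1` is the only compound of the set with a number in an assay on cells for inhibition of Amine oxidase [flavin-containing] B (Rattus norvegicus); a higher number here means a weaker inhibitor, a lower number a stronger inhibitor; there compound 1 gives 1070 nM. Compound 2 `O=C(Nc1ccc(F)c(F)c1)c1ccc2cn[nH]c2c1` in this assay gives < 10000 nM, which is a limit of the assay and not a number. The step from compound 1 to compound 2, fluoro in place of chloro on an aromatic carbon, is a step that the limit leaves unreadable from compound 1 to compound 2 because of the limit of < 10000 nM in this assay, at which 1 of the 2 values shown sits.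

Compound 3 `COc1ccc(NC(=O)c2ccc3cn[nH]c3c2)cc1Cl` differs from compound 1 by methoxy in place of fluoro on an aromatic carbon. For the measured compounds named here, no measured step reads on this change, so no step beyond the scatter is expected: a 1.1-fold lower number from compound 1 to compound 3 (0.03 log units; within the scatter). Compound 3 is therefore expected to give about 1000 nM, with a range from 300 nM to 4000 nM.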

Compound 3, half-maximal inhibitory concentration: < 10000 nM
Compound 3: no number, only a limit; the forecaster's own chance of this, stated with the estimate: 10%; the middle value lies beyond the limit too.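

No new step can be read from compound 1 to compound 3, because compound 3 gives only a limit in this assay, not a number: the limit of < 10000 nM in this assay, at which 2 of the 3 values shown sit.

The compounds shown leave open whether compound 2 or compound 3 is stronger or weaker than compound 1.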